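Cytotoxicity on removing a chain methyl

The compounds below may be only part of what the source reports. "The series", "measured", "known", "first", "only" and "open" are said of these compounds alone.

Measured in an ADME assay on MT4 cells (Homo sapiens) for cytotoxicity, read by MTT assay; a lower number here means that less compound is tolerated, a higher number that more compound is tolerated:
compound 1 `Cc1c(N)nc(Nc2ccc(C#N)cc2)nc1Cc1c(F)cccc1F`: 45900 nM
compound 2 `Cc1c(Cl)nc(Nc2ccc(C#N)cc2)nc1C(C)c1c(F)cccc1F`: > 13000 nM

The entry for compound 2 is a limit and not a number: the limit of > 13000 nM in this assay, at which 1 of the 2 values shown sits. Compound 3 `Cc1c(Cl)nc(Nc2ccc(C#N)cc2)nc1Cc1c(F)cccc1F` carries hydrogen in place of methyl on a saturated chain carbon bound to two aromatic carbons. Among the measured compounds shown here, no measured step covers this change, and the only actual number is compound 1 at 45900 nM. The expected step that the limit leaves unreadable from compound 2 to compound 3 is small, towards more compound tolerated in this assay. For compound 3 the estimate is 25000 nM, with an expected range of 11000 nM to 60000 nM.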

Compound 3, half-maximal cytotoxic concentration: > 2690 nM
Compound 3 was reported as a limit; the forecaster's own chance of this, stated with the estimate: 45%; the middle value does not contradict the limit.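

In this assay no step can be read among compound 1, compound 2 and compound 3; the entries for compound 2 and compound 3 are limits. The compounds shown leave open the size of both changes: hydrogen in place of methyl on the chain carbon, and chloro in place of amino.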